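Swapping the Side Group Once More on a Shared Core

The source may hold more compounds than are shown below. What is called first, only, known or untested is meant among the compounds shown, and "the series" means these compounds.

Compound 2 `Cc1nn(-c2ncnc3nc[nH]c23)c2c1C(c1ccc(OC(C)C)cc1)CC(=O)N2` carries a 4-isopropoxyphenyl group on a saturated ring carbon of its core. In a functional assay on HEK293 cells for agonist activity at G-protein coupled receptor 39 (Homo sapiens), read by scintillation proximity assay and inositol phosphate accumulation, with a stated time of 75 min (a higher number here means that more compound is needed for the effect, a lower number that less compound is needed), compound 2 gives 2700 nM. Among the two measured compounds this is the lowest number, yet its only neighbour, compound 1 `Cc1nn(-c2ncnc3nc[nH]c23)c2c1C(C(=O)NCc1ccccc1)CC(=O)N2`, gives 2930 nM in this assay, and the two numbers sit within the scatter of each other. The step between them, a 1.1-fold lower number from compound 1 to compound 2 (0.04 log units; within the scatter), already replaced one group at that same saturated ring carbon with another and made no difference beyond the scatter.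

Compound 3 `Cc1nn(-c2ncnc3nc[nH]c23)c2c1C(OCc1ccc(C#N)cc1)CC(=O)N2` is not yet measured. It differs from compound 2 in one place: (4-cyanobenzyl)oxy in place of 4-isopropoxyphenyl on a saturated ring carbon. Among the measured compounds shown here, only one measured step bears on this change: the swap at the same saturated ring carbon from compound 1 to compound 2 left the number essentially where it was. A single such step is thin ground, so the expectation is broad: the step of a 1.1-fold higher number from compound 2 to compound 3 (0.05 log units; within the scatter) is expected to be small, with no clear direction. Compound 3 is therefore estimated at 3000 nM in this assay, with a range from 900 nM to 10000 nM.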

Compound 3, half-maximal effective concentration: 60 nM
Compound 3: the middle estimate sits 50-fold (1.70 log units) above what was measured; measured number outside the range, below it.
By their numbers in this assay, from the lowest: compound 3; then compounds 2 and 1 (each within the scatter of the next).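

The saturated ring carbon of the shared core is not indifferent to what it carries. In this assay the (4-cyanobenzyl)oxy group brings a 45-fold lower number from compound 2 to compound 3 (1.65 log units; beyond the scatter) and a 49-fold lower number from compound 1 to compound 3 (1.69 log units; beyond the scatter), both large and beyond the scatter, whereas the earlier swap at this same carbon produced no change beyond the scatter. The large step from 4-isopropoxyphenyl to (4-cyanobenzyl)oxy comes with no change in the count of heavy atoms or in the single six-membered aromatic ring, so those counts alone do not separate a weak group from a much stronger one here, and no measurement at hand accounts for the step.

The compounds shown do not tell which part of the entering group goes with the lower number: the nitrile, the oxygen on the ring carbon, or the whole group together. From the compounds shown here alone, a plain benzyloxy group, a benzyloxy group with chlorine in place of the nitrile, and a 4-cyanobenzyl group joined through an amine instead of the oxygen would each separate these parts, and their numbers remain open.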